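The source may hold more compounds than are shown below. What is called first, only, known or untested is meant among the compounds shown, and "the series" means these compounds.

In a functional assay on HeLa cells (Homo sapiens) for cytotoxicity, read by MTT assay, with a stated time of 2 days, tested at 100 uM (on this read-out lower numbers stand for a stronger effect and higher numbers for a weaker effect at the one concentration tested), compound 1 `COc1ccc(-c2cc3cc(-c4ccccc4)cc(C(C)=O)c3[nH]2)cc1` gives 32.8% and compound 2 `COc1ccc(-c2cc3cc(-c4ccc(F)cc4)cc(C(C)=O)c3[nH]2)cc1` gives 46.5%, the higher of the two numbers, meaning the weaker effect. Going by the values given here, the one measured step, a number 13.7 percentage points higher from compound 1 to compound 2 (beyond the scatter), shows that a single change on this scaffold moved the read-out modestly. Compound 3 `COc1ccc(-c2cc(C(C)=O)c3[nH]c(-c4ccc(OC)cc4)cc3c2)cc1` differs from compound 2 by methoxy in place of fluoro on an aromatic carbon. Among the compounds with values here, no measured step covers methoxy entering in place of fluoro, so the only guide is the modest size of that one step. The expected step, a number 1.5 percentage points lower from compound 2 to compound 3 (within the scatter), is therefore small, not clearly beyond the scatter. Compound 3 is estimated at 45%, within a range from 28% to 65%.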

Compound 3, a percentage reported as activity, at one concentration (the size of the read-out at that concentration, not a potency): 20.2%
Estimate against measurement, compound 3: 24.8 percentage points above; the measured number lies below the stated range.
By their numbers in this assay, from the lowest: compound 3; then compound 1; then compound 2.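

At this place on the aromatic ring, the read-out can move in either direction. In this assay, methoxy in place of fluoro gives a number 26.3 percentage points lower from compound 2 to compound 3 (beyond the scatter), and methoxy in place of hydrogen gives a number 12.6 percentage points lower from compound 1 to compound 3 (beyond the scatter), so methoxy gives a stronger effect here, whereas fluoro gave a weaker one. Nothing available explains why the two groups differ.

From the compounds shown here alone, whether an amine or a longer chain such as ethoxy at this place would give a stronger or weaker effect remains open. Three compounds cannot establish a general trend across groups.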